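Triazole series: carbamoyl in place of dimethyl-oxazole on aryl

A few compounds are considered here, and "the series" means these few. Any claim that something is new, unique, unknown or untested is made for them only; others in the source may bear on it.

Notes on the aryl substituent of the shared core. In an assay on isolated protein for inhibition of 11-beta-hydroxysteroid dehydrogenase type 2 (Homo sapiens) (a lower number here means a stronger inhibitor, a higher number a weaker inhibitor), compound 1 `Cn1c(-c2ccc(C(=O)NC3CC3)cc2)nnc1C1(c2ccc(Cl)cc2)CCC1` gives > 4000 nM, which is a limit of the assay rather than a number. In this assay compound 2 `Cc1noc(C)c1-c1ccc(-c2nnc(C3(c4ccc(Cl)cc4)CCC3)n2C)cc1` gives > 4000 nM, also a limit. The step that the two limits leave unreadable from compound 1 to compound 2 cannot be read in size, since both ends sit at the limit of > 4000 nM in this assay, at which 2 of the 2 values shown sit. Compound 2 thus stands at the limit, with no numerical value to place it against anything.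

Compound 3 `Cn1c(-c2ccc(C(=O)NC(C)(C)C)cc2)nnc1C1(c2ccc(Cl)cc2)CCC1` differs from compound 2 as (tert-butyl)carbamoyl in place of 3,5-dimethyl-1,2-oxazol-4-yl on an aromatic carbon. Among the compounds with values here, the only measured step bearing on it is the unreadable one from compound 1 to compound 2. Compound 3 returns to a carbamoyl group of the same kind as in compound 1, which sits at the limit. With both measured compounds at the limit of > 4000 nM in this assay, at which 2 of the 2 values shown sit, no step beyond the scatter can be expected in this assay, and compound 3 is expected most likely to report a limit as well. The estimate for compound 3 is 8000 nM with range 3000 nM to 30000 nM, corresponding to an expected step that the limit leaves unreadable from compound 2 to compound 3.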

Compound 3, half-maximal inhibitory concentration: > 4000 nM
Compound 3 gave a limit, no number; the forecaster's own chance of this, stated with the estimate: 85%; the middle value lies beyond the limit too.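

In this assay compound 3 gives > 4000 nM, a limit and not a number. Its steps from compound 1 and compound 2 therefore cannot be read in size: the limit of > 4000 nM in this assay, at which 3 of the 3 values shown sit.

The compounds shown leave open whether any aryl substituent on the shared core gives a numerical value in this assay, and how compounds 1, 2 and 3 rank against one another.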